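The compounds below may be only part of what the source reports. "The series", "measured", "known", "first", "only" and "open" are said of these compounds alone.

Working notes on a series built on one shared core. In a functional assay on HeLa cells (Homo sapiens) for cytotoxicity, read by MTT assay, with a stated time of 72 h (a higher number here means a weaker inhibitor, a lower number a stronger inhibitor), compound 1 `CCCOc1ccc2cc(C(=O)NCCO)c(=O)oc2c1` gives 22600 nM and compound 2 `CCN(CC)c1ccc2cc(C(=O)NN)c(=O)oc2c1` gives 5480 nM. Compound 3 `CCOc1ccc2cc(C(=O)NN)c(=O)oc2c1` gives 38300 nM, the highest of the three numbers, with compound 1 within the scatter of it and compound 2 beyond it. Going by the values given here, the one measured single-point step, a 7.0-fold higher number from compound 2 to compound 3 (0.84 log units; beyond the scatter), alters the group on the aromatic carbon, not the chain, so it bears only loosely on what follows. Compound 4 `CCCOc1ccc2cc(C(=O)NN)c(=O)oc2c1` differs from compound 3 by methyl in place of hydrogen on a saturated chain carbon, two bonds along the chain from an oxygen on an aromatic ring. Compound 1, which also carries propoxy though with a different amide end, sits within the scatter of compound 3. The step of a 1.2-fold lower number from compound 3 to compound 4 (0.08 log units; within the scatter) is therefore expected to stay within the scatter. Compound 4 is estimated at 32000 nM, range 13000 nM to 80000 nM.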

Compound 4, half-maximal inhibitory concentration: > 100000 nM
Compound 4: a limit, no number (the forecaster's own chance of this, stated with the estimate: 10%); at least 3.1-fold (0.49 log units) between middle value and limit.
By their numbers in this assay, from the lowest: compound 2; then compounds 1 and 3 (each within the scatter of the next). At a limit, above all of these: compound 4.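

In this assay compound 4 is a limit of the assay, not a number: the limit of > 100000 nM in this assay, at which 1 of the 4 values shown sits. Methyl added to the saturated chain carbon gives an at least 2.6-fold higher number from compound 3 to compound 4 (0.41 log units; beyond the scatter) and so shows that this position, not probed on its own by the earlier compounds, responds to one added carbon. The other steps read an at least 18-fold higher number from compound 2 to compound 4 (1.26 log units; beyond the scatter) and an at least 4.4-fold higher number from compound 1 to compound 4 (0.64 log units; beyond the scatter) and the latter shows that, with propoxy held, amino in place of 2-hydroxyethyl on the amide-type nitrogen also raises the number.

The limit leaves the full size of each step open. As far as these compounds go, whether a butoxy chain or a terminal amine on the chain would behave alike also remains open.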